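Benzyl for furanylmethyl amide on the shared core

The compounds below may be only part of what the source reports. "The series", "measured", "known", "first", "only" and "open" are said of these compounds alone.

Compound 1 `N[C@H]1CC[C@H](Nc2c(C(=O)NCc3ccco3)nc(Br)c3cccnc23)CC1` is the reference point of this series. Among the compounds with values here, in a functional assay on SK-BR-3 cells (Homo sapiens) for cytotoxicity, read by MTT assay, with a stated time of 72 h (a higher number here means a weaker inhibitor, a lower number a stronger inhibitor), compound 1 gives 10000 nM, which is the only actual number recorded, so compound 1 sits at the one measured level the series offers. Within the data shown here, compound 2 `NCCCNc1c(C(=O)NCc2ccc(F)cc2)ncc2cccnc12` differs from compound 1 at several places at once, so no single step can be drawn between them. For compound 2 the read-out in this assay is a limit of the assay, > 10000 nM, and not a number. That reading is one of the two values sitting at the limit (the limit of > 10000 nM in this assay, at which 1 of the 2 values shown sits).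

Compound 3 `N[C@H]1CC[C@H](Nc2c(C(=O)NCc3ccccc3)nc(Br)c3cccnc23)CC1` is still to be measured. Against compound 1 the change is phenyl in place of furan-2-yl on a saturated chain carbon bound to an amide-type nitrogen. Among the measured compounds shown here, no step between measured compounds exists here, so the expectation rests on compound 1 alone. The expected step of a 1.2-fold higher number from compound 1 to compound 3 (0.08 log units; within the scatter) in this assay is small, within the usual scatter, with no clear direction. Compound 3 is therefore estimated at 12000 nM, in a range from 4000 nM to 40000 nM, with a fair chance that this assay returns only a limit instead of a number.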

Compound 3, half-maximal inhibitory concentration: 8000 nM
Compound 3: the middle estimate sits 1.5-fold (0.18 log units) above what was measured, and the stated range covers the measured number.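

In this assay, within the data shown here, the first readable step at this position is a 1.3-fold lower number from compound 1 to compound 3 (0.10 log units; within the scatter), so phenyl in place of furan-2-yl on a saturated chain carbon bound to an amide-type nitrogen gives no change that can be told from the scatter. The exchange of a five-membered aromatic ring with 1 hetero atom for a six-membered aromatic ring of carbon only, which also removes the hydrogen-bond acceptor counted on furan-2-yl, therefore leaves no readable mark on this read-out, and (furan-2-yl)methyl and benzyl stand level here. Compound 2 remains a limit of the assay and not a number: the limit of > 10000 nM in this assay, at which 1 of the 3 values shown sits.

Still open, going by these compounds, is whether any other group on this saturated chain carbon moves the number beyond the scatter, for instance a cyclohexyl in place of the aromatic ring, a longer chain before the ring, or a benzyl carrying a carboxylic acid. Among these compounds, also open is what the other places on the shared core contribute, as compound 2 differs from compound 1 at several places at once and offers no single step.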